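The compounds below may be only part of what the source reports. "The series", "measured", "known", "first", "only" and "open" are said of these compounds alone.

Compound 3 `Cc1ccc2ncc(S(=O)(=O)c3ccc(C)c(F)c3)c(N3CCC(C)CC3)c2c1` is one of three closely related sulfones in which a 4-methylpiperidine sits on the shared core. In an assay on isolated protein for displacement of a labelled ligand from metabotropic glutamate receptor 5 (Homo sapiens), with a stated time of 60 min, tested at 1 uM (on this read-out higher numbers stand for more inhibition at the one concentration tested (going by the name of the read-out) and lower numbers for less inhibition), compound 3 gives 91%, level with compound 2 `Cc1ccc2ncc(S(=O)(=O)c3ccc(C)c(Cl)c3)c(N3CCC(C)CC3)c2c1`, which gives 91%, and the two together stand highest of the three, while compound 1 `COc1cccc(S(=O)(=O)c2cnc3ccc(F)cc3c2N2CCC(C)CC2)c1` gives 90%, a value that lies within the scatter of both.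

Compound 4 `COc1cccc(S(=O)(=O)c2cnc3ccc(C)cc3c2N2CCC(C)CC2)c1` has not yet been measured. It differs from compound 3 in one place: 3-methoxyphenyl in place of 3-fluoro-4-methylphenyl on a sulfonyl sulfur

Among the measured compounds shown here, the single step measured so far on the ring attached to the sulfonyl sulfur is no change at the digits printed from compound 2 to compound 3 (within the scatter), a swap of one halogen for another that left the read-out unmoved. Compound 1 already carries the 3-methoxyphenyl ring that enters in compound 4, on a core that differs from that of compound 4 only elsewhere, and its value sits within the scatter of compound 3. Both facts point the same way: the step from compound 3 to compound 4 is expected to be a number 1 percentage points lower from compound 3 to compound 4 (within the scatter), that is, none beyond the scatter. Compound 4 is therefore estimated to give 90% in this assay, with a range from 80% to 97%.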

Compound 4, a percentage reported as inhibition, at one concentration (the size of the read-out at that concentration, not a potency): 96%
Compound 4: middle estimate off by 6 percentage points, on the low side, and the stated range covers the measured number.
By their numbers in this assay, from the lowest: compounds 1, 2, 3 and 4 (each within the scatter of the next).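

In this assay, 3-methoxyphenyl in place of 3-fluoro-4-methylphenyl on a sulfonyl sulfur gives a number 5 percentage points higher from compound 3 to compound 4 (within the scatter) and 3-methoxyphenyl in place of 3-chloro-4-methylphenyl gives a number 5 percentage points higher from compound 2 to compound 4 (within the scatter) so this position takes a ring with 1 hydrogen-bond acceptor in place of one with 0 hydrogen-bond acceptors, and the read-out shows no step beyond the scatter. The earlier compounds had shown only one halogen exchanged for another at this position, whereas these steps replace both the halogen and the methyl of the ring. The change elsewhere, methyl in place of fluoro on an aromatic carbon, gives a number 6 percentage points higher from compound 1 to compound 4 (within the scatter) and so also stays within the scatter with the 3-methoxyphenyl ring in place, while nothing available bears on what lies behind these numbers.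

A single read-out at one concentration is not a potency, so any real order among these four compounds remains open. Going by these compounds, it also remains open whether the sulfonyl sulfur would carry a phenyl ring bearing a carboxylic acid or an amine as well, and whether morpholine could stand in for the 4-methylpiperidine.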